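One side chain changes: cyclopropyl gives way to isobutyl

The compounds below may be only part of what the source reports. "The series", "measured", "known", "first", "only" and "open" are said of these compounds alone.

- compound 1 (`O=C1c2ccc(OCc3cccc(-c4ccc(Cl)cc4F)c3)cc2CN1C1CCCC1`) gives "not determined" (no result reported)
- compound 2 (`O=C(O)c1cc(-c2cccc(COc3ccc4c(=O)n(CC5CC5)sc4c3)c2)ccc1Cl`) gives 100%

Going by the values given here, in an ADME assay on a cell-free system (plasma, Rattus norvegicus) for metabolic stability, read by LC-MS, with a stated time of 1 h, at 37 degrees C, tested at 100 uM (a higher number here means that more of the compound is left, a lower number that less of the compound is left), compound 2 gives 100% and that is the only number so far. Compound 1 has no result, so compound 2 cannot be ranked against anything.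

Compound 3 (`CC(C)CCn1sc2cc(OCc3cccc(-c4ccc(Cl)c(C(=O)O)c4)c3)ccc2c1=O`) differs from compound 2 in one place (isobutyl in place of cyclopropyl on a saturated chain carbon bound to an aromatic nitrogen): isobutyl in place of cyclopropyl on a saturated chain carbon bound to an aromatic nitrogen. Cut one bond further out, the same difference reads cyclopropylmethyl to isopentyl.

Among the compounds with values here, no measured step shows what such a swap does in this assay, so the expectation rests on compound 2 alone, with its 100% leaving little room upward. A slight downward drift, but nothing beyond the scatter, is expected. The estimate means a number 3 percentage points lower from compound 2 to compound 3 (within the scatter) as the expected change. Compound 3 is expected at 97% (estimated range 86% to 105%).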

Compound 3, percent of the compound remaining: 91%
Compound 3: the middle estimate sits 6 percentage points above what was measured; low and high end bracket the measured number.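

In this assay, going by these compounds alone, the first step at this position gives a number 9 percentage points lower from compound 2 to compound 3 (within the scatter), on a saturated chain carbon bound to an aromatic nitrogen. A three-membered ring of carbon leaves here and an isobutyl group without a ring enters, with one more carbon, and the step stays inside the normal spread of repeat measurements. So for this one pair, the ring is not needed to keep the read-out within that spread. Nothing measured here explains the size of this step.
Going by these compounds, with a single step at this position, it remains open whether the same would hold for a longer chain, a hydroxyl group or an amine on this carbon. On these data alone, it also remains open whether this swap would behave the same on a different core.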